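Amino for Ester on the Benzyl Ring of a Trimethoxyaniline

A few compounds are considered here, and "the series" means these few. Any claim that something is new, unique, unknown or untested is made for them only; others in the source may bear on it.

Measured compounds:
compound 1 `COc1ccc(CN(C(=O)CCCl)c2cc(OC)c(OC)c(OC)c2)cc1O` gives 110 nM
compound 2 `COC(=O)c1cc(CNc2cc(OC)c(OC)c(OC)c2)ccc1OC` gives 41100 nM
compound 3 `COCC(=O)N(Cc1ccc(OC)c(O)c1)c1cc(OC)c(OC)c(OC)c1` gives 460 nM

In a functional assay on KYSE-450 cells (Homo sapiens) for inhibition, read by MTT assay, with a stated time of 48 h (on this read-out lower numbers stand for stronger inhibition and higher numbers for weaker inhibition), compound 2 stands at the highest number of the three, far from compound 3 and furthest from compound 1, both gaps beyond the scatter. Going by the values given here, compound 1 and compound 3 share the shared core with compound 2 but carry an amide chain and a hydroxy group where compound 2 has a free amine linker and a methoxycarbonyl group; the one measured step, a 4.2-fold higher number from compound 1 to compound 3 (0.62 log units; beyond the scatter), concerns only the acyl chain and does not touch the ring substituent.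

Compound 4 `COc1ccc(CNc2cc(OC)c(OC)c(OC)c2)cc1N` differs from compound 2 in one place: amino in place of methoxycarbonyl on an aromatic carbon. Among the compounds with values here, no measured step isolates this change, so its size cannot be read from the data; it is only noted that the two potent compounds carry a small group on that same aromatic carbon while compound 2 carries a larger one. The account therefore expects a modest move toward a lower number, with wide uncertainty. Compound 4 is estimated at 8000 nM, between 1500 nM and 40000 nM, which is expected to mean a 5.1-fold lower number from compound 2 to compound 4 (0.71 log units; beyond the scatter).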

Compound 4, half-maximal inhibitory concentration: 2210 nM
Estimate against measurement, compound 4: 3.6-fold (0.56 log units) above; the measured number falls inside the stated range.
By their numbers in this assay, from the lowest: compound 1; then compound 3; then compound 4; then compound 2.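

In this assay, going by these compounds alone, replacing methoxycarbonyl with amino on this aromatic carbon, ortho to a methoxy group, gives a 19-fold lower number from compound 2 to compound 4 (1.27 log units; beyond the scatter) and is the first measured change at this position, as the earlier step touched only the acyl chain. The step is large and comes from a single change of group, with the free amine linker and the rest of the structure held the same, so this position clearly matters on this read-out, at least in this pair. Nothing shown here indicates which difference between methoxycarbonyl and amino accounts for the step.

The compounds shown leave open whether a carboxylic acid or a dimethylamino group on this aromatic carbon would stand nearer to compound 2 or to compound 4, and how hydroxy would compare with amino on the same free amine linker. They also leave open whether amino would bring a similar gain on an acylated nitrogen, since compound 1 and compound 3 differ from compound 4 in more than one place and cannot be compared with it as a single step.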